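The source may report more compounds than this note shows. Statements on the series, on what has been measured and on what is new or still open speak of the compounds shown alone.

Compound 1, `CSc1ccc(/C(=N\O)c2cccc3ccccc23)cc1`: in a functional assay on Ishikawa cells (Homo sapiens) for antiproliferative activity, read by MTT assay, with a stated time of 24 h (a higher number here means that more compound is needed for the effect, a lower number that less compound is needed), compound 1 gives > 50000 nM, which is a limit of the assay and not a number.
Compound 2, `CCOC(=O)CO/N=C(\c1ccc(SC)cc1)c1cccc2ccccc12`: in this assay compound 2 gives > 50000 nM, again a limit.
Compound 3, `CCCCN(C)CCCO/N=C(\c1ccc(SC)cc1)c1cccc2ccccc12`: in this assay compound 3 gives > 50000 nM, again a limit.

Compound 3 therefore stands at no definite point; its result in this assay is only a limit, shared with the other two compounds, as the limit of > 50000 nM in this assay, at which 3 of the 3 values shown sit, records. The steps between the measured compounds cannot be read: a step that the two limits leave unreadable from compound 1 to compound 2, a step that the two limits leave unreadable from compound 1 to compound 3 and a step that the two limits leave unreadable from compound 2 to compound 3 are all hidden by the two limits.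

Compound 4, `CCN(CCCCO/N=C(\c1ccc(SC)cc1)c1cccc2ccccc12)Cc1ccccc1`, differs from compound 3 by (benzyl(ethyl)amino)methyl in place of butyl(methyl)amino on a saturated chain carbon, three bonds along the chain from an oxygen on an unsaturated carbon. Within the data shown here, no measured step gives a readable size for a change of this kind at this position, so the expectation for compound 4 rests on the three limits alone. Because the three compounds all sit at the limit in the limit of > 50000 nM in this assay, at which 3 of the 3 values shown sit, compound 4 is expected to give an estimated 50000 nM in this assay, with a range from 8000 nM to 150000 nM, and most likely only a limit again. The step from compound 3 to compound 4 is accordingly expected to be a number no higher from compound 3 to compound 4 (the limit leaves the size open), with a number above the limit the likeliest outcome.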

Compound 4, half-maximal effective concentration: > 50000 nM
Compound 4 gave a limit, no number; the forecaster's own chance of this, stated with the estimate: 70%; the middle value lies on the limit itself.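

No new step can be read between compound 3 and compound 4, as both results are limits and not numbers: the limit of > 50000 nM in this assay, at which 4 of the 4 values shown sit.

The compounds shown leave open what actual value each compound has, and so whether any of these changes matters.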